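Phenylsulfonyl to (1-methylcyclohexyl)carbonyl at the amine nitrogen

The source may report more compounds than this note shows. Statements on the series, on what has been measured and on what is new or still open speak of the compounds shown alone.

Measured so far:
compound 1 `COc1ccnc(NC[C@@H]2C[C@@H](OCC(=O)NC[C@H](NC(=O)C3(C)CCCCC3)C(=O)O)CN2C(=O)OCc2ccccc2)c1`: 0.8 nM
compound 2 `O=C(CO[C@@H]1C[C@@H](CNc2ccccn2)N(C(=O)OCc2ccccc2)C1)NC[C@H](NS(=O)(=O)c1ccccc1)C(=O)O`: 86 nM

In an assay on a protein complex for inhibition of integrin alpha-5/beta-1 (Homo sapiens), read by ELISA (a higher number here means a weaker inhibitor, a lower number a stronger inhibitor), compound 2 stands at the higher of the two numbers, and its nearest neighbour is compound 1, whose value is far lower, with the gap between the two well beyond the scatter.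

Compound 3 `CC1(C(=O)N[C@@H](CNC(=O)CO[C@@H]2C[C@@H](CNc3ccccn3)N(C(=O)OCc3ccccc3)C2)C(=O)O)CCCCC1` is not yet measured. It differs from compound 2 in one place: (1-methylcyclohexyl)carbonyl in place of phenylsulfonyl on an amine nitrogen. For the measured compounds named here, the entering group is the one carried by compound 1, which in this assay gives 0.8 nM.

Going by the values given here, no measured pair isolates this exact change, so the expectation rests on compound 1 bearing the same amide. A large step downward is expected from compound 2 to compound 3, estimated at a 43-fold lower number from compound 2 to compound 3 (1.63 log units; beyond the scatter), clearly beyond the scatter. For compound 3 the estimate in this assay is 2 nM, with a range from 0.5 nM to 8 nM.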

Compound 3, half-maximal inhibitory concentration: 1.7 nM
Estimate against measurement, compound 3: 1.2-fold (0.07 log units) above, within the range that was stated.
By their numbers in this assay, from the lowest: compound 1; then compound 3; then compound 2.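

In this assay, the change from phenylsulfonyl to (1-methylcyclohexyl)carbonyl on the amine nitrogen now stands alone on an otherwise unchanged structure and gives a 51-fold lower number from compound 2 to compound 3 (1.70 log units; beyond the scatter) as a large step, so this position by itself has a strong effect on the number. Hydrogen in place of methoxy on an aromatic carbon gives a 2.1-fold higher number from compound 1 to compound 3 (0.33 log units; beyond the scatter) as a modest step, which shows that the low number of the amide series does not rest on the methoxy group. No supporting data bear on the origin of either step.

For the compounds shown here, with only two groups compared at the amine nitrogen, it remains open whether the ring or the linking carbonyl matters more, which a cyclohexylcarbonyl or a benzoyl group would address. From the compounds shown here alone, how a methyl or a chlorine in place of the methoxy would read also remains open.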